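A few compounds are considered here, and "the series" means these few. Any claim that something is new, unique, unknown or untested is made for them only; others in the source may bear on it.

Three compounds of the series carry a number in a functional assay on the whole organism with Rattus norvegicus as the target, at a dose of 20 mg/kg by the oral route; a lower number here means less inhibition, a higher number more inhibition at the dose given (going by the name of the read-out). Compound 1 `NC(=O)/C=C1\CCc2c(F)cccc21` gives 34%, compound 2 `CNC(=O)/C=C1\CCc2ccc(Br)cc21` gives 53%, and compound 3 `O=C(/C=C1\CCc2ccc(F)cc21)NCC1CC1` gives 21%. Compound 3 stands lowest of the three: the gap up to compound 1 lies beyond the scatter, and the larger gap up to compound 2 lies beyond it as well. Compound 4 `O=C(/C=C1\CCc2ccc(F)cc21)NCCO` is not yet measured. It differs from compound 3 in one place: hydroxymethyl in place of cyclopropyl on a saturated chain carbon bound to an amide-type nitrogen. Within the data shown here, no measured pair shows this change, so nothing in the numbers speaks for a move in either direction. The step expected here, a number 6 percentage points higher from compound 3 to compound 4 (within the scatter), is taken as none beyond the scatter. Compound 4 is estimated at 27% in this assay, with a range from 8% to 48%.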

Compound 4, a percentage reported as inhibition, in the whole organism at one dose (the size of the read-out at that dose, not a potency): 78%
Estimate against measurement, compound 4: 51 percentage points below; the measured number lies above the stated range.
By their numbers in this assay, from the lowest: compound 3; then compound 1; then compound 2; then compound 4.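

In this assay, hydroxymethyl in place of cyclopropyl on a saturated chain carbon bound to an amide-type nitrogen gives a number 57 percentage points higher from compound 3 to compound 4 (beyond the scatter). Among these compounds, this is the first pair that differs in one place, and it shows that the read-out at the dose given responds strongly to this change. Nothing available gives a reason for the step.

The change removes the ring and brings in the oxygen together, so the pair cannot tell which of the two carries the step. As far as these compounds go, whether an amine, a carboxylic acid or methoxymethyl in place of hydroxymethyl would hold the number also remains open.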